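A cyclohexyl group replaces a thiophene on compound 2

A few compounds are considered here, and "the series" means these few. Any claim that something is new, unique, unknown or untested is made for them only; others in the source may bear on it.

Of the compounds shown here, two have so far been measured in an ADME assay on a cell-free system (serum) for metabolic stability; on this read-out higher numbers stand for a longer-lived compound and lower numbers for a shorter-lived compound. Compound 1 `CC(C)(C)c1cc(OC(=O)c2ccc(Cl)cc2)ccc1O` gives < 0.25 h, which is a limit of the assay and not a number. Compound 2 `CC(C)(C)c1cc(NC(=O)c2c(Cl)cc(NCc3cccs3)cc2Cl)ccc1O` gives > 1 h, which is likewise a limit of the assay. On these data alone, compound 2 therefore stands at the long-lived end of the two values shown, though its exact half-life remains unknown.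

Compound 3 `CC(C)(C)c1cc(NC(=O)c2c(Cl)cc(NC3CCCCC3)cc2Cl)ccc1O` keeps the rest of compound 2 but carries cyclohexyl in place of (thiophen-2-yl)methyl on a nitrogen on an aromatic ring. Among the compounds with values here, no measured pair of compounds shows what such an exchange does, so any forecast is uncertain. Within the data shown here, the only close guide is compound 2, whose limit reads > 1 h. No step beyond the usual scatter is therefore expected in this assay, and the estimated change is a step that the limit leaves unreadable from compound 2 to compound 3. For compound 3 the expected half-life is 2 h, with an estimated range of 1 h to 6 h.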

Compound 3, half-life: > 1 h
Compound 3 ended at the assay's limit (the forecaster's own chance of this, stated with the estimate: 80%); the middle value lies beyond the limit too.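

Compound 2 and compound 3 both stand at a limit of this assay, so no step between them can be read: the limit of > 1 h in this assay, at which 2 of the 3 values shown sit.

The compounds shown leave open what the half-life of either compound is, and so whether cyclohexyl in place of (thiophen-2-yl)methyl on a nitrogen on an aromatic ring changes it at all.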